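Phenethyloxy Replaces Butoxy on the Biphenyl Amide

The source may report more compounds than this note shows. Statements on the series, on what has been measured and on what is new or still open speak of the compounds shown alone.

In an assay on isolated protein for agonist activity at Bile acid receptor (Homo sapiens), read by TR-FRET, with a stated time of 3 h, in the absence of a further agent (on this read-out lower numbers stand for an effect already at smaller amounts and higher numbers for an effect only at larger amounts of compound), compound 1 `Cc1cccc(COc2ccc(C(=O)Nc3cccc(C(=O)O)c3)cc2)c1` gives 259 nM. Compound 2 `CCCCOc1cccc(-c2cccc(C(=O)Nc3cccc(C(=O)O)c3)c2)c1` gives 256 nM in this assay, the lowest of the two numbers shown, though its gap to compound 1 lies within the scatter. Compound 3 `O=C(O)c1cccc(NC(=O)c2cccc(-c3cccc(OCCc4ccccc4)c3)c2)c1` is not yet measured. It differs from compound 2 by phenyl in place of ethyl on a saturated chain carbon, two bonds along the chain from an oxygen on an aromatic ring. Among the compounds with values here, no measured pair shows such a step, so the expected step is the estimate a 1.4-fold lower number from compound 2 to compound 3 (0.15 log units; within the scatter), small and toward lower numbers if any. Compound 3 is expected at 180 nM, within 60 nM to 550 nM.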

Compound 3, half-maximal effective concentration: 169 nM
For compound 3 the middle estimate is 1.1-fold (0.03 log units) above the measured one; the range from low to high includes it.
By their numbers in this assay, from the lowest: compounds 3, 2 and 1 (each within the scatter of the next).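

Replacing butoxy with phenethyloxy at this position gives a 1.5-fold lower number from compound 2 to compound 3 (0.18 log units; within the scatter) in this assay. A six-membered aromatic ring of carbon only can therefore stand in place of ethyl on this saturated chain carbon while the number stays within the scatter, which the two earlier compounds could not show. Nothing at hand explains the size of this step.

On these data alone, whether an amine or a carboxylic acid on the entering phenyl would move the number beyond the scatter remains open. So does the effect of a longer chain between that phenyl and the oxygen.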